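Swapping a Ring-Fused Group for a Simple Anilino

This account rests on a few compounds, and the source may have more. Where it says the series, first, only, none or still open, it means among the compounds named here.

Compound 1 `O=C1c2ccccc2CN1c1cnc(NCc2c(F)ccc3c2CCO3)n2cnnc12` and compound 2 `Cc1cc(-c2cnc(NCc3c(F)ccc4c3CCO4)c3cn[nH]c(=O)c23)n(C)n1` share a core and the same fluorinated bicyclic arm joined through a methylene and an amine. In an ADME assay on microsomes from liver (Homo sapiens) for metabolic stability, read by LC-MS, using NADPH, with stated times of 5 min and 30 min, tested at 1 uM (on this read-out higher numbers stand for fast clearance and lower numbers for slow clearance), compound 1 gives 13 mL.min-1.g-1, the lower of the two numbers recorded, while compound 2 gives 24 mL.min-1.g-1; the two values sit within the usual scatter of each other, so no order between them can be claimed.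

Compound 3 `Fc1ccc2c(c1CNc1ncc(Nc3ccccc3)c3nncn13)CCO2` keeps the fluorinated arm and the core of compound 1 and differs in one place: a group of 7 heavy atoms (6 carbon, 1 nitrogen; one six-membered aromatic ring of carbon only) in place of a group of 10 heavy atoms (8 carbon, 1 nitrogen, 1 oxygen; one five-membered non-aromatic ring with 1 hetero atom, one six-membered aromatic ring of carbon only), on an aromatic carbon. No measured pair shows a change of this kind, so the size of its effect is unknown from the data shown. For compound 3 in this assay a modest rise is expected, a step of a 1.5-fold higher number from compound 1 to compound 3 (0.19 log units; within the scatter) that may well stay within the scatter, giving an estimate of 20 mL.min-1.g-1, with a range from 8 mL.min-1.g-1 to 50 mL.min-1.g-1.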

Compound 3, intrinsic clearance in microsomes: 20 mL.min-1.g-1
Compound 3: middle estimate and measured number agree at the digits printed; low and high end bracket the measured number.
By their numbers in this assay, from the lowest: compounds 1, 3 and 2 (each within the scatter of the next).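

At this position, on an aromatic carbon of the shared core, the step from the larger ring-fused group to the smaller anilino group is a 1.5-fold higher number from compound 1 to compound 3 (0.19 log units; within the scatter) in this assay and so cannot be told apart from repeat-to-repeat noise. This single change therefore shows that, in this pair, the ring-fused group can give way to a plain anilino group, with its one hydrogen-bond donor, without a measurable shift in clearance. Nothing in the data explains this result or shows which part of either molecule is being broken down.

Only one replacement at this position is shown, so it remains open whether a phenoxy group, a morpholine ring or a carboxylic acid there would also leave clearance unchanged. The compounds shown also leave open how changes to the fluorinated arm would affect this read-out.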